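Compound 4: ethoxy in place of benzyloxy, cytotoxicity

A few compounds are considered here, and "the series" means these few. Any claim that something is new, unique, unknown or untested is made for them only; others in the source may bear on it.

Measured in an ADME assay on HepG2 cells (Homo sapiens) for cytotoxicity, read by CellTiter-Glo and resazurin assay, with a stated time of 72 h; a lower number here means that less compound is needed, a higher number that more compound is needed for the effect:
compound 1 `CC(=O)Nc1cccc(-c2ccc(C(=O)N(Cc3cccc(OCCCCCC(=O)O)c3)C(C)C)cc2)c1` — > 26000 nM
compound 2 `CC(C)N(Cc1cccc(OCCCCCC(=O)O)c1)C(=O)c1ccc(-c2ccsc2)cc1` — > 26000 nM
compound 3 `CC(C)N(Cc1cccc(OCCCCCC(=O)O)c1)C(=O)c1ccc(-c2cccc(OCc3ccccc3)c2)cc1` — > 26000 nM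

Each of these values is a limit of this assay, not a number. Compound 3 therefore stands only at a limit, and the two other values shown are limits as well; all three sit at the same limit (the limit of > 26000 nM in this assay, at which 3 of the 3 values shown sit). The step from compound 1 to compound 2 in this assay is a step that the two limits leave unreadable from compound 1 to compound 2, and the step from compound 1 to compound 3 is a step that the two limits leave unreadable from compound 1 to compound 3; neither gives a readable size, so neither tells how far any compound lies beyond the limit.

Compound 4 `CCOc1cccc(-c2ccc(C(=O)N(Cc3cccc(OCCCCCC(=O)O)c3)C(C)C)cc2)c1` differs from compound 3 by methyl in place of phenyl on a saturated chain carbon bound to an oxygen on an aromatic ring, that is, benzyloxy to ethoxy. For the measured compounds named here, no measured step touches this saturated chain carbon, so no step bears directly on the change; the only guidance is that every compound so far sits at the limit (the limit of > 26000 nM in this assay, at which 3 of the 3 values shown sit).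

Compound 4 is expected to remain at the limit of this assay, with the step from compound 3 to compound 4 expected to be a step that the limit leaves unreadable from compound 3 to compound 4, nothing beyond the scatter. The estimate for compound 4 in this assay is 30000 nM, with a range from 13000 nM to 100000 nM.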

Compound 4, half-maximal effective concentration: > 20800 nM
Compound 4 ended at the assay's limit (the forecaster's own chance of this, stated with the estimate: 85%); the middle value is on the limit's open side.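

In this assay compound 4 gives > 20800 nM, which is a limit and not a number. Its steps from compound 1, compound 2 and compound 3 therefore cannot be read. The compounds shown leave open how far any of the four lies beyond its limit, and which change, if any, would give a readable value.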